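Naphthyl for methoxyphenyl: an untested step in a series

A few compounds are considered here, and "the series" means these few. Any claim that something is new, unique, unknown or untested is made for them only; others in the source may bear on it.

Compound 3 `COc1ccc(C2=NN(C3=NC(=O)/C(=C4\C(=O)Nc5ccccc54)S3)C(c3ccc(Cl)cc3)C2)cc1` gives 86600 nM in a functional assay on cells (Leukemia cell, Homo sapiens) for cytotoxicity, read by sulforhodamine B assay, with a stated time of 48 h (on this read-out higher numbers stand for weaker inhibition of growth and lower numbers for stronger inhibition of growth), the highest of the three numbers recorded. Compound 1 `COc1ccc(C2CC(c3ccc4ccccc4c3)=NN2C2=NC(=O)/C(=C3\C(=O)Nc4ccccc43)S2)cc1` gives 17500 nM in this assay, and compound 2 `O=C1N=C(N2N=C(c3ccccc3)CC2c2ccc(Cl)cc2)S/C1=C1/C(=O)Nc2ccccc21` gives 370 nM. For the measured compounds named here, the one single-point step measured runs a 230-fold higher number from compound 2 to compound 3 (2.37 log units; beyond the scatter), so removing that methoxy would be expected to bring the number far down. Compound 4 `O=C1N=C(N2N=C(c3ccc4ccccc4c3)CC2c2ccc(Cl)cc2)S/C1=C1/C(=O)Nc2ccccc21` carries naphthalen-2-yl in place of 4-methoxyphenyl on a carbon with a double bond to nitrogen. Going by the values given here, no measured pair isolates the naphthalen-2-yl for a phenyl or 4-methoxyphenyl exchange at that carbon; compound 1, which also bears naphthalen-2-yl, differs from compound 2 in two places, so its value alone cannot be read as a step. Compound 4 keeps the 4-chlorophenyl of compound 2 while losing the methoxy that compound 3 carries, so a large downward step is expected, though with wide uncertainty because compound 1 sits at 17500 nM. Compound 4 is therefore estimated at 3000 nM, within 500 nM to 20000 nM, a step of a 29-fold lower number from compound 3 to compound 4 (1.46 log units; beyond the scatter) expected from compound 3.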

Compound 4, concentration for 50% growth inhibition: 19100 nM
Beside the measured number, compound 4's estimate is 6.4-fold (0.80 log units) below it, within the range that was stated.
By their numbers in this assay, from the lowest: compound 2; then compounds 1 and 4 (each within the scatter of the next); then compound 3.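

In this assay, the carbon with a double bond to nitrogen can now be read with three groups while the 4-chlorophenyl group stays fixed. Naphthalen-2-yl in place of phenyl raises the number sharply (a 52-fold higher number from compound 2 to compound 4 (1.71 log units; beyond the scatter)), whereas naphthalen-2-yl in place of 4-methoxyphenyl lowers it only modestly (a 4.5-fold lower number from compound 3 to compound 4 (0.66 log units; beyond the scatter)), so phenyl gives the lowest number of the three and both larger groups stand well above it. With naphthalen-2-yl at this carbon, chloro in place of methoxy on the other aromatic ring makes no difference beyond the scatter (a 1.1-fold higher number from compound 1 to compound 4 (0.04 log units; within the scatter)).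

Nothing available explains these steps. On these data alone, it remains open whether a pyridin-3-yl ring or a small alkyl chain such as ethyl at this carbon would keep a number as low as that of compound 2 (370 nM).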